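The compounds below may be only part of what the source reports. "The series", "measured", "known", "first", "only" and "open" are said of these compounds alone.

Measured in a functional assay on KG-1 cells (Homo sapiens) for cytotoxicity, read by luminescence and CellTiter-Glo, with a stated time of 3 days; a higher number here means a weaker inhibitor, a lower number a stronger inhibitor:
- compound 1 `O=C(Nc1ccc(Cl)cc1Cl)c1cc(F)ccc1O`: 850 nM
- compound 2 `N#Cc1ccc(NC(=O)c2ccc(-c3ccccc3)cc2O)cc1`: 410 nM
- compound 3 `CN(C(=O)c1cc(F)ccc1O)c1ccc(C#N)cc1`: > 10000 nM, a limit of the assay

Among the two actual numbers, compound 1 stands highest at 850 nM, while compound 2 gives 410 nM, a lower number by a gap beyond the usual scatter.

Compound 4 `O=C(Nc1ccc([N+](=O)[O-])cc1Cl)c1cc(F)ccc1O` has nitro in place of chloro on an aromatic carbon, meta to a chloro group and para to a large group (nitro in place of chloro on an aromatic carbon). For the measured compounds named here, no measured pair shows this change directly. The nearest guide is compound 2, which has a nitrile instead of chloro, among other differences, and gives 410 nM. A modest expected step toward a lower number in this assay is therefore estimated as a 2.1-fold lower number from compound 1 to compound 4 (0.33 log units; beyond the scatter). For compound 4 the expected value is 400 nM, with an estimated range from 130 nM to 1300 nM.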

Compound 4, half-maximal inhibitory concentration: 490 nM
Compound 4: the middle estimate sits 1.2-fold (0.09 log units) below what was measured; the range from low to high includes it.
By their numbers in this assay, from the lowest: compounds 2, 4 and 1 (each within the scatter of the next, the first and the last beyond it). At a limit, above all of these: compound 3.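

At this position, para to a large group, nitro in place of chloro gives a 1.7-fold lower number from compound 1 to compound 4 (0.24 log units; within the scatter) in this assay, so the two compounds cannot be told apart. The earlier compounds shown here held no direct pair for this change, and here nitro, with 3 heavy atoms against 1 for chloro, leaves the value within the scatter. Nothing shown here gives a reason for this result.

Open, from the compounds shown here alone, is whether an amine or a carboxylic acid in the same place would also stay within the scatter of chloro. Also open, going by these compounds, is whether the result holds without the chloro group that stays meta to this position.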